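From Compound 3 to Compound 4: A Longer Chain

The compounds below may be only part of what the source reports. "The series", "measured", "known", "first", "only" and "open" are said of these compounds alone.

Measured so far in a functional assay on the whole organism (S2 cells, strain S2) for inhibition, with Drosophila as the target, read by a luciferase reporter, with stated times of 1.5 h and 8 h; on this read-out higher numbers stand for weaker inhibition and lower numbers for stronger inhibition...
compound 1 `CCCCCCCC(=O)c1c(OC)c(Cl)c(OC)c(Cl)c1OC` gives 15300 nM
compound 2 `CCCCCC(=O)c1c(O)cc(OC)c(Cl)c1O` gives 4600 nM
compound 3 `CCCC(=O)c1c(O)c(Cl)c(O)c(Cl)c1O` gives 21500 nM

Compound 3 stands with compound 1 at the upper end of these numbers, the two lying within the scatter of each other, while compound 2 has a number lower than compound 3 by more than the scatter. Compound 4 (`CCCCCCCC(=O)c1c(O)c(Cl)c(O)c(Cl)c1O`) has not yet been measured. It differs from compound 3 only in the chain: butyl in place of hydrogen on a saturated chain carbon, three bonds along the chain from a carbonyl carbon. Going by the values given here, no measured pair differs in one place alone, so any forecast is loose. Compound 2 (4600 nM) suggests that a chain longer than that of compound 3 may go with stronger inhibition, but its core differs too. Compound 1 (15300 nM) carries the chain of compound 4 on a differently substituted core and urges caution. A modest step toward stronger inhibition is therefore expected in this assay, only slightly beyond the scatter. The expected change is a 2.4-fold lower number from compound 3 to compound 4 (0.38 log units; beyond the scatter) on this reasoning. For compound 4 the estimated value is 9000 nM (expected range 3000 nM to 25000 nM).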

Compound 4, half-maximal inhibitory concentration: 3700 nM
Estimate against measurement, compound 4: 2.4-fold (0.39 log units) above; the range from low to high includes it.
By their numbers in this assay, from the lowest: compounds 4 and 2 (each within the scatter of the next); then compounds 1 and 3 (each within the scatter of the next).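

Going by these compounds alone, the new result supplies the first pair in this set that differs in one place alone: in this assay, butyl in place of hydrogen on a saturated chain carbon, three bonds along the chain from a carbonyl carbon, gives a 5.8-fold lower number from compound 3 to compound 4 (0.76 log units; beyond the scatter). This modest step lies beyond the scatter, so on this shared core the position tolerates the added butyl and the change goes with stronger inhibition. Nothing shown gives a measured reason for the change.

Within the data shown here, with only this one step at the position, it remains open whether inhibition changes gradually with chain length, as ethyl or a longer chain in place of the butyl could show. Also unsettled is whether the position needs a plain carbon chain at all, or would accept an amine or a carboxylic acid at the end of it.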